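Aminomethyl step carried from one amide core to another

A few compounds are considered here, and "the series" means these few. Any claim that something is new, unique, unknown or untested is made for them only; others in the source may bear on it.

Compound 1 `O=C(Nc1ccccc1)c1cc2cc([N+](=O)[O-])ccc2o1` and compound 2 `NCc1ccccc1NC(=O)c1cc2cc([N+](=O)[O-])ccc2o1` share one core; compound 3 `O=C(Nc1ccccc1)c1cnc2ccccc2c1` and compound 4 `NCc1ccccc1NC(=O)c1cnc2ccccc2c1` share another. The difference between the two cores is not broken down here. In a physicochemical assay for solubility (a higher number here means a more soluble compound, a lower number a less soluble compound), compound 1 gives 25 ug/mL, while compound 2 gives 5 ug/mL. The step of a 5.0-fold lower number from compound 1 to compound 2 (0.70 log units; beyond the scatter) follows the change (aminomethyl in place of hydrogen on an aromatic carbon). In this assay compound 3 gives 5 ug/mL; this is level with compound 2, the two values within the scatter of each other, and together they are the lowest of the three numbers, with compound 1 standing a step beyond the scatter above them.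

Compound 4 differs from compound 3 by aminomethyl in place of hydrogen on an aromatic carbon. Both place descriptions read the same word for word, so this is the same change that separates compound 1 from compound 2; it occurs twice among the compounds shown and has been measured only once. For compound 4 the expected step is a 5.0-fold lower number from compound 3 to compound 4 (0.70 log units; beyond the scatter), taken as close in size to the single measured precedent a 5.0-fold lower number from compound 1 to compound 2 (0.70 log units; beyond the scatter), since nothing else among these compounds bears on the change. Because compound 3 starts from 5 ug/mL, compound 4 is expected to come out at about 1 ug/mL, with a plausible span from 0.3 ug/mL to 4 ug/mL. One precedent on a different core is a thin base, and a reading that low may come back only as a limit of the assay.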

Compound 4, solubility: 5 ug/mL
The estimate for compound 4 lay 5.0-fold (0.70 log units) below the measured number; measured number outside the range, above it.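

In this assay, aminomethyl in place of hydrogen on an aromatic carbon gives no change at the digits printed from compound 3 to compound 4 (within the scatter), whereas the same change on the other core gives a 5.0-fold lower number from compound 1 to compound 2 (0.70 log units; beyond the scatter), so the step seen on the first core did not carry over to the second. For the compounds shown here, this shows that, across the two pairs available, the change has no single size: its step lies beyond the scatter on one core and within it on the other, and the single precedent gave no safe basis for a transfer between the two cores. It does not show which of the two pairs is more typical of the series, nor does it establish that the outcome follows the core rather than something else that differs between the pairs, and no measurement among those available bears on why the two steps part.

The compounds shown leave open how the same change would read on a third core, which would help show whether either step recurs. Going by these compounds alone, they also leave open whether a longer chain such as aminoethyl, or a carboxylic acid, in place of the aminomethyl would follow the step on the first core or the step on the second.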